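The compounds below may be only part of what the source reports. "The series", "measured", "known", "first", "only" and "open" are said of these compounds alone.

Working notes on the series, following the step from compound 3 to compound 4.

Compound 1 `COc1ccccc1C(=O)Nc1nc(-c2ccccc2)nc2c1nnn2Cc1ccccc1` gives 1520 nM in an assay (strain Wistar) for displacement of a labelled ligand from adenosine receptor A1 (Rattus norvegicus), read by scintillation counting; a higher number here means a weaker inhibitor, a lower number a stronger inhibitor. Compound 2 `O=C(Nc1nc(-c2ccccc2)nc2c1nnn2Cc1ccccc1)c1ccccc1C(F)(F)F` gives 550 nM in this assay, the step of a 2.8-fold lower number from compound 1 to compound 2 (0.44 log units; beyond the scatter) coming from the trifluoromethyl in place of methoxy on an aromatic carbon. Compound 3 `O=C(Nc1nc(-c2ccccc2)nc2c1nnn2Cc1ccccc1)C1CCCCC1` gives 12 nM in this assay and stands lowest of the three numbers, with compound 2 nearest and compound 1 furthest. Both steps into it, a 130-fold lower number from compound 1 to compound 3 (2.10 log units; beyond the scatter) and a 46-fold lower number from compound 2 to compound 3 (1.66 log units; beyond the scatter), are large, and both replace an aryl group on the carbonyl carbon with cyclohexyl.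

Compound 4 `O=C(Nc1nc(-c2ccccc2)nc2c1nnn2Cc1ccccc1)c1cccc(C(F)(F)F)c1` is not yet measured. Its change from compound 3 is 3-(trifluoromethyl)phenyl in place of cyclohexyl on a carbonyl carbon. This runs opposite to the two large steps of a 130-fold lower number from compound 1 to compound 3 (2.10 log units; beyond the scatter) and a 46-fold lower number from compound 2 to compound 3 (1.66 log units; beyond the scatter), which are the measurements that bear on it: both aryl amides measured so far gave numbers far higher than the cyclohexyl amide. A large upward step in this assay is therefore expected for compound 4, though the incoming group is neither of the two aryl groups measured, so where it falls among them is open. The expected step is a 25-fold higher number from compound 3 to compound 4 (1.40 log units; beyond the scatter). For compound 4 the estimate in this assay is 300 nM, with a range from 80 nM to 1500 nM.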

Compound 4, inhibition constant: 163 nM
The estimate for compound 4 lay 1.8-fold (0.26 log units) above the measured number; the measured number falls inside the stated range.
By their numbers in this assay, from the lowest: compound 3; then compound 4; then compound 2; then compound 1.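

In this assay the third aryl group behaves as the first two did: a 14-fold higher number from compound 3 to compound 4 (1.13 log units; beyond the scatter), so on this carbonyl carbon the cyclohexyl amide stays below all three aryl amides shown, now including one with the trifluoromethyl group placed differently on the ring. The aryl amides also separate from one another, since the change to 3-(trifluoromethyl)phenyl gives a 3.4-fold lower number from compound 2 to compound 4 (0.53 log units; beyond the scatter) and a 9.3-fold lower number from compound 1 to compound 4 (0.97 log units; beyond the scatter), which shows that where the trifluoromethyl group sits on the phenyl ring changes the number and leaves compound 4 lowest among the aryl amides, though still short of the cyclohexyl amide. Nothing available gives any reason for these differences.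

The compounds shown leave open whether any aryl amide can reach the cyclohexyl amide, as an unsubstituted phenyl group would give the baseline against which all three substituted rings could be read. They also leave open whether the gain belongs to the six-membered ring of carbon itself, which a cyclopentyl group or an open hexyl chain on the same carbonyl carbon would test.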